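Ether substituent swap in a phosphatase series

The source may hold more compounds than are shown below. What is called first, only, known or untested is meant among the compounds shown, and "the series" means these compounds.

Compound 2 `O=C1NC(=S)S/C1=C\C=C\c1ccccc1OCc1ccncc1` stands lowest of the two numbers in an assay on isolated protein for inhibition of protein tyrosine phosphatase type IVA 3 (Homo sapiens), tested at 5 ug/mL (a lower number here means less inhibition, a higher number more inhibition at the concentration tested (going by the name of the read-out)), where compound 2 gives 39.4%; compound 1 `COc1ccccc1COc1ccccc1/C=C/C=C1\SC(=S)NC1=O` gives 78.8%. Among the compounds with values here, the single measured step, a number 39.4 percentage points lower from compound 1 to compound 2 (beyond the scatter), was large. Compound 3 `O=C1NC(=S)S/C1=C\C=C\c1ccccc1OCc1ccccc1Br` differs from compound 2 by 2-bromophenyl in place of pyridin-4-yl on a saturated chain carbon bound to an oxygen on an aromatic ring. This change reverses the kind of swap that lowered compound 1 to compound 2, putting a six-membered aromatic ring of carbon only back in the same place, so a rise in this assay is expected, roughly of the size seen between compound 1 and compound 2. Compound 3 is therefore estimated at 68%, range 42% to 90%, which means an expected step of a number 28.6 percentage points higher from compound 2 to compound 3 (beyond the scatter).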

Compound 3, a percentage reported as inhibition, at one concentration (the size of the read-out at that concentration, not a potency): 63.1%
Compound 3: middle estimate off by 4.9 percentage points, on the high side; measured number inside the range.
By their numbers in this assay, from the lowest: compound 2; then compound 3; then compound 1.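

In this assay, 2-bromophenyl in place of pyridin-4-yl on the saturated chain carbon recovers part of the earlier loss, with a number 23.7 percentage points higher from compound 2 to compound 3 (beyond the scatter). The carbon-only ring does not settle the number alone: bromo in place of methoxy on an aromatic carbon gives a number 15.7 percentage points lower from compound 1 to compound 3 (beyond the scatter), so the substituent on that ring also matters. No supporting data explain either step.

Still open, on these data alone, is how an unsubstituted phenyl ring would read at this position. A carboxylic acid or a dimethylamino group on the ring is also untested among the compounds shown, and these single-concentration percentages give no potencies.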